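Adding a Second Methoxy Group to the Pyrazole-Side Ring

The compounds below may be only part of what the source reports. "The series", "measured", "known", "first", "only" and "open" are said of these compounds alone.

Measured so far:
Compound 1 `COc1ccc(-c2cc(/C=C/C(=O)c3ccc(N)cc3)[nH]n2)cc1`, 4910 nM
Compound 2 `COc1cc(-c2cc(/C=C/C(=O)c3ccc(Cl)c(Cl)c3)[nH]n2)cc(OC)c1OC`, 23500 nM
Compound 3 `COc1ccc(C(=O)/C=C/c2cc(-c3cc(OC)c(OC)c(OC)c3)n[nH]2)cc1OC`, 3930 nM

In a functional assay on CCRF-CEM cells (Homo sapiens) for inhibition, read by sulforhodamine B assay, with a stated time of 48 h (a higher number here means a weaker inhibitor of growth, a lower number a stronger inhibitor of growth), compound 1 stands second highest of the three numbers, within the scatter of compound 3 and clearly below compound 2. Compound 4 `COc1ccc(-c2cc(/C=C/C(=O)c3ccc(N)cc3)[nH]n2)cc1OC` differs from compound 1 by methoxy in place of hydrogen on an aromatic carbon. Within the data shown here, the only step that is known, a 6.0-fold lower number from compound 2 to compound 3 (0.78 log units; beyond the scatter), concerns the ring on the carbonyl carbon, not the ring that changes here, so no step bears directly on the change from compound 1 to compound 4. Without such evidence, compound 4 is expected to stay close to compound 1, with a 1.1-fold lower number from compound 1 to compound 4 (0.04 log units; within the scatter) lying within the scatter. Compound 4 is therefore estimated at 4500 nM in this assay, in a range of 1800 nM to 11000 nM.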

Compound 4, concentration for total growth inhibition: 7810 nM
Estimate against measurement, compound 4: 1.7-fold (0.24 log units) below; the range from low to high includes it.
By their numbers in this assay, from the lowest: compounds 3, 1 and 4 (each within the scatter of the next); then compound 2.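

At this position, ortho to a methoxy group and meta to a large group, methoxy in place of hydrogen gives a 1.6-fold higher number from compound 1 to compound 4 (0.20 log units; within the scatter) in this assay, the only step shown on this ring. The added methoxy group therefore makes no change beyond the scatter here, whereas the change on the carbonyl carbon gives a 6.0-fold lower number from compound 2 to compound 3 (0.78 log units; beyond the scatter). Nothing measured here bears on what lies behind this result.

On these data alone, whether a hydroxy group or a longer ethoxy chain at this position would also stay within the scatter remains open. So does whether the added methoxy group would give a similar step with a 3,4-dimethoxyphenyl group on the carbonyl carbon.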